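The source may report more compounds than this note shows. Statements on the series, on what has been measured and on what is new or still open speak of the compounds shown alone.

Measured compounds in a functional assay on A549 cells (Homo sapiens) for antiproliferative activity, with a stated time of 72 h, tested at 50 ug/mL; on this read-out lower numbers stand for a weaker effect and higher numbers for a stronger effect at the one concentration tested:
compound 1 `O=c1[nH]nc2n(c1=O)CCN2c1ccccc1`: 17%
compound 2 `Cc1ccccc1N1CCn2c1n[nH]c(=O)c2=O`: 29%
compound 3 `Cc1ccc(N2CCn3c2n[nH]c(=O)c3=N)cc1`: 38%

Compound 3 and compound 2 do not share one core with a single counted difference; how the two cores differ is not broken down here. Between compound 2 and compound 1 the change is hydrogen in place of methyl on an aromatic carbon, and in this assay this step gives a number 12 percentage points lower from compound 2 to compound 1 (beyond the scatter). Compound 4 `N=c1c(=O)[nH]nc2n1CCN2c1ccccc1` is not yet measured; it arises from compound 3 by hydrogen in place of methyl on an aromatic carbon. This is the same kind of change as that from compound 2 to compound 1, but the place differs: ortho to a large group in the earlier pair, para to a large group here. Among the measured compounds shown here, because the only measured instance gave a number 12 percentage points lower from compound 2 to compound 1 (beyond the scatter), a step of similar size is expected from compound 3 to compound 4 in this assay, namely a number 12 percentage points lower from compound 3 to compound 4 (beyond the scatter). For the measured compounds named here, compound 4 is thus estimated at 26% in this assay, with a range from 12% to 38%, the single precedent and the differing place leaving the estimate uncertain.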

Compound 4, a percentage reported as inhibition, at one concentration (the size of the read-out at that concentration, not a potency): 38%
Estimate against measurement, compound 4: 12 percentage points below, within the range that was stated.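

In this assay, hydrogen in place of methyl para to a large group gives no change at the digits printed from compound 3 to compound 4 (within the scatter) on this core. Set beside the earlier step, the result does not separate the two cores: the same change on two cores in this assay, a number 12 percentage points lower (beyond the scatter) from compound 2 to compound 1 and no change at the digits printed (within the scatter) from compound 3 to compound 4, 12 percentage points apart, within the scatter of two such steps. The change can therefore be neither called transferable with a fixed size nor called dependent on the core, and with the place of the methyl also differing between the two pairs, core and place cannot be told apart.

Still open, as far as these compounds go, is how a methyl para to a large group behaves on the core of compound 1. Also open, from the compounds shown here alone, is how a chlorine, a methoxy group or an amine on the same aromatic ring compares with methyl and hydrogen.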